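This account rests on a few compounds, and the source may have more. Where it says the series, first, only, none or still open, it means among the compounds named here.

Compound 1 `Cc1cc(-c2ccnc(C(F)F)c2)ncc1OC[C@@](C)(N)CC(C)C` is the stronger of the two measured compounds in an assay on isolated protein for inhibition of AP2-associated protein kinase 1 (Homo sapiens), with a stated time of 3 h, in the presence of a further agent that is not named here (on this read-out higher numbers stand for weaker inhibition and lower numbers for stronger inhibition), where compound 1 gives 1.4 nM. Its companion compound 2 `CC(C)C[C@H](N)COc1ccc(-c2ccnc(NCc3ccccc3)c2)cc1`, which differs from compound 1 in several places, is far weaker: in this assay compound 2 gives 127 nM, a gap well beyond the scatter, though with no single change between them nothing more can be read from the pair. The next compound, compound 3 `COC(=O)Nc1cc(-c2cc(C)c(OC[C@@](C)(N)CC(C)C)cn2)ccn1`, keeps the core of compound 1 and alters one position ((methoxycarbonyl)amino in place of difluoromethyl on an aromatic carbon), on an aromatic carbon of a six-membered aromatic ring with one nitrogen, next to the ring nitrogen. Going by the values given here, no measured pair shows this change, so the size of the step is open. Compound 3 is expected to hold the potency of compound 1, with any step a 1.4-fold lower number from compound 1 to compound 3 (0.15 log units; within the scatter) staying within or near the scatter. Compound 3 is estimated in this assay at 1 nM, in a range from 0.3 nM to 4 nM.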

Compound 3, half-maximal inhibitory concentration: 1.7 nM
Compound 3: the middle estimate sits 1.7-fold (0.23 log units) below what was measured; the measured number falls inside the stated range.
By their numbers in this assay, from the lowest: compounds 1 and 3 (each within the scatter of the next); then compound 2.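

In this assay the exchange of difluoromethyl for (methoxycarbonyl)amino gives a 1.2-fold higher number from compound 1 to compound 3 (0.08 log units; within the scatter), so this position, on an aromatic carbon next to the ring nitrogen, accepts the change with no shift that can be told from the scatter. The entering group has 5 heavy atoms against 3 for the one it replaces, and it brings a double bond, a hydrogen-bond donor and hydrogen-bond acceptors that difluoromethyl lacks, so none of these features costs a measurable step here. Nothing available explains why the number holds.

The compounds shown leave open whether a free amine, a methoxy group or a carboxylic acid at this position would hold the number as well. They also leave open whether a longer chain on the nitrogen of the (methoxycarbonyl)amino group would still fit this pattern.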